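The source may report more compounds than this note shows. Statements on the series, on what has been measured and on what is new or still open speak of the compounds shown alone.

Three compounds have been measured in a functional assay on MIA PaCa-2 cells (Homo sapiens) for antiproliferative activity, read by WST assay, with a stated time of 72 h; a higher number here means a weaker inhibitor, a lower number a stronger inhibitor:

Compound 1 `COc1ccc2[nH]c(-c3nc(-c4ccc(Cl)cc4)no3)cc2c1` gives 22700 nM.
Compound 2 `Fc1ccc2[nH]c(-c3nc(-c4ccc(Cl)cc4)no3)cc2c1` gives > 50000 nM, which is a limit of the assay and not a number.
Compound 3 `COc1ccc(-c2noc(-c3cc4cc(OC)ccc4[nH]3)n2)cc1` gives 5600 nM.

The change fluoro in place of methoxy on an aromatic carbon made an at least 2.2-fold higher number from compound 1 to compound 2 (0.34 log units; beyond the scatter); the step can only be bounded because of the limit of > 50000 nM in this assay, at which 1 of the 3 values shown sits. The core of compound 3 differs from the core of compound 1 by methoxy in place of chloro on an aromatic carbon, a change that gave a 4.1-fold lower number from compound 1 to compound 3 (0.61 log units; beyond the scatter). Compound 4 `COc1ccc(-c2noc(-c3cc4cc(F)ccc4[nH]3)n2)cc1` has not yet been measured. It differs from compound 3 by fluoro in place of methoxy on an aromatic carbon, the same change as that from compound 1 to compound 2, at the same place. Since the earlier step was at least modest and only bounded, compound 4 is expected to show a 2.7-fold higher number from compound 3 to compound 4 (0.43 log units; beyond the scatter), resting on the step from compound 1 to compound 2. Compound 4 is therefore estimated at 15000 nM, likely between 6000 nM and 50000 nM.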

Compound 4, half-maximal inhibitory concentration: 10300 nM
Beside the measured number, compound 4's estimate is 1.5-fold (0.16 log units) above it, within the range that was stated.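

Fluoro in place of methoxy gave a 1.8-fold higher number from compound 3 to compound 4 (0.26 log units; within the scatter), so on this core the change does not stand clear of the scatter, and it cannot be told apart from the earlier step: the same change on two cores in this assay, an at least 2.2-fold higher number (0.34 log units; beyond the scatter) from compound 1 to compound 2 and a 1.8-fold higher number (0.26 log units; within the scatter) from compound 3 to compound 4; the limit leaves it open whether they differ

Methoxy in place of chloro gave an at least 4.8-fold lower number from compound 2 to compound 4 (0.68 log units; beyond the scatter), the same direction as on the other core: the same change on two cores in this assay, a 4.1-fold lower number (0.61 log units; beyond the scatter) from compound 1 to compound 3 and an at least 4.8-fold lower number (0.68 log units; beyond the scatter) from compound 2 to compound 4; the limit leaves it open whether they differ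

Compound 2 gives > 50000 nM, which is a limit of the assay and not a number, so neither comparison shows that the size of a step carries over from one core to another.

The compounds shown carry only methoxy or fluoro at the one varied place and only chloro or methoxy at the other. On these data alone, how an amine or a carboxylic acid would behave at either place in this assay stays open.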